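The compounds below may be only part of what the source reports. "The series", "measured", "known", "first", "only" and "open" are said of these compounds alone.

Measured so far in a functional assay on heart right ventricle (Rattus norvegicus, strain WKY), tested at 10 uM; a lower number here means a stronger effect, a higher number a weaker effect of the compound at the concentration tested:
compound 1 `CCCCO[C@H](c1ccc(O)c(O)c1)[C@H](CC#Cc1ccc(O)c(O)c1)O[C@@H]1O[C@H](CO)[C@@H](O)[C@H](O)[C@H]1O`, for which compound 1 gives 95.4%
compound 2 `CCCCO[C@@H](c1ccc(O)c(O)c1)[C@H](CC#Cc1ccc(O)c(O)c1)O[C@@H]1O[C@H](CO)[C@@H](O)[C@H](O)[C@H]1O`, for which compound 2 gives 96.8%
compound 3 `OC[C@H]1O[C@@H](O[C@@H](CC#Cc2ccc(O)c(O)c2)[C@H](O)c2ccc(O)c(O)c2)[C@H](O)[C@@H](O)[C@@H]1O`, for which compound 3 gives 78.2%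

Compound 3 holds the lowest of the three numbers in this assay, the step being a number 17.2 percentage points lower from compound 1 to compound 3 (beyond the scatter); compounds 1 and 2 sit together, a number 1.4 percentage points higher from compound 1 to compound 2 (within the scatter), which fits (the fact that compounds 1 and 2 differ only in the configuration as drawn).

The next compound, compound 4 `OC[C@H]1O[C@@H](O[C@@H](CC#Cc2ccc(O)cc2)[C@H](O)c2ccc(O)c(O)c2)[C@H](O)[C@@H](O)[C@@H]1O`, carries hydrogen in place of hydroxy on an aromatic carbon relative to compound 3. Neither measured step touches an aromatic hydroxy, so neither bears directly on this change; the stereochemical step was within the scatter and the ether-to-alcohol step modest. The expectation is a small shift toward a higher number, possibly within the scatter: a number 8.8 percentage points higher from compound 3 to compound 4 (within the scatter). Compound 4 is estimated at 87%, with a range of 72% to 100%.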

Compound 4, a percentage reported as activity, at one concentration (the size of the read-out at that concentration, not a potency): 95.2%
Compound 4: the middle estimate sits 8.2 percentage points below what was measured; the measured number falls inside the stated range.
By their numbers in this assay, from the lowest: compound 3; then compounds 4, 1 and 2 (each within the scatter of the next).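

In this assay, the change from 3,4-dihydroxyphenyl to 4-hydroxyphenyl gives a number 17 percentage points higher from compound 3 to compound 4 (beyond the scatter), the first sign that a substituent on an aromatic ring matters in this series. The lower number of compound 3 therefore depends on this hydroxy, just as a number 17.2 percentage points lower from compound 1 to compound 3 (beyond the scatter) ties it to the oxygen without its butyl group. Nothing at hand gives a reason for this step.

On these data alone, whether the hydroxy on the other aromatic ring carries similar weight stays open. As far as these compounds go, it is also open whether a methoxy or a fluorine at this position would keep the lower number.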